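Swapping Trifluoromethyl for Fluoro on the Aromatic Ring

The compounds below may be only part of what the source reports. "The series", "measured", "known", "first", "only" and "open" are said of these compounds alone.

Compound 3 `O=C(CCCCCCc1nc(-c2ccc(C(F)(F)F)cc2)no1)C(F)(F)F` stands second highest of the three numbers measured in an assay on isolated protein for inhibition of histone deacetylase 8 (Homo sapiens), read by fluorescence, with a stated time of 10 min (on this read-out lower numbers stand for stronger inhibition and higher numbers for weaker inhibition), where compound 3 gives 1030 nM. Compound 1 `O=C(CCCCCCc1nc(-c2ccccc2)no1)C(F)(F)F` gives 760 nM and compound 2 `COc1ccc(-c2noc(CCCCCCC(=O)C(F)(F)F)n2)cc1` gives 1860 nM. Compound 4 `O=C(CCCCCCc1nc(-c2ccc(F)cc2)no1)C(F)(F)F` differs from compound 3 by fluoro in place of trifluoromethyl on an aromatic carbon. Three earlier steps changed the same aromatic carbon: a 1.4-fold higher number from compound 1 to compound 3 (0.13 log units; within the scatter) and a 1.8-fold lower number from compound 2 to compound 3 (0.26 log units; within the scatter) both stayed within the scatter, while a 2.4-fold higher number from compound 1 to compound 2 (0.39 log units; beyond the scatter) was modest. Changes at this carbon have so far moved the number little, so the step to compound 4 is expected to remain within the scatter, with no clear direction. Compound 4 is therefore expected to give about 900 nM, in a range from 450 nM to 1800 nM. The expected step is a 1.1-fold lower number from compound 3 to compound 4 (0.06 log units; within the scatter).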

Compound 4, half-maximal inhibitory concentration: 7650 nM
For compound 4 the middle estimate is 8.5-fold (0.93 log units) below the measured one; measured number outside the range, above it.
By their numbers in this assay, from the lowest: compounds 1, 3 and 2 (each within the scatter of the next, the first and the last beyond it); then compound 4.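

In this assay, among the compounds shown here, this aromatic carbon proves far less forgiving than the earlier compounds suggested, with a 7.4-fold higher number from compound 3 to compound 4 (0.87 log units; beyond the scatter) and a 4.1-fold higher number from compound 2 to compound 4 (0.61 log units; beyond the scatter) and also a 10-fold higher number from compound 1 to compound 4 (1.00 log units; beyond the scatter) making compound 4 the weakest of the four. Group size alone does not order these numbers: compound 1, with hydrogen, and compound 3, with trifluoromethyl, lie within the scatter of each other, while fluoro stands apart from both.

From the compounds shown here alone, whether chloro or a nitrile here would track fluoro or trifluoromethyl stays open, as does whether fluoro elsewhere on this ring gives the same rise. Nothing measured here accounts for the behaviour of fluoro.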